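This account rests on a few compounds, and the source may have more. Where it says the series, first, only, none or still open, it means among the compounds named here.

Three compounds share one core and differ only in the group carried on an aromatic carbon of the fused ring. Compound 1 `CCCn1c(=O)c2nc([C@@H]3CC4C=CC3C4)[nH]c2n(CCC)c1=O` gives 4.3 nM in an assay on cell membranes for binding affinity to adenosine receptor A1 (Cavia porcellus), read by radioligand binding; a higher number here means a weaker inhibitor, a lower number a stronger inhibitor. Compound 2 `CCCn1c(=O)c2nc(C(C)(C)C)[nH]c2n(CCC)c1=O` gives 31 nM, a step of a 7.2-fold higher number from compound 1 to compound 2 (0.86 log units; beyond the scatter). Compound 3 `CCCn1c(=O)c2nc(-c3ccco3)[nH]c2n(CCC)c1=O` gives 560 nM, which is the highest of the three numbers: it lies an 18-fold higher number from compound 2 to compound 3 (1.26 log units; beyond the scatter) and a 130-fold higher number from compound 1 to compound 3 (2.11 log units; beyond the scatter).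

Compound 4 `CCCn1c(=O)c2nc(C(C)(O)CC)[nH]c2n(CCC)c1=O` is the next compound, not yet measured. Its change from compound 3 is 1-hydroxy-1-methylpropyl in place of furan-2-yl on an aromatic carbon. The group that enters has no ring, like the tert-butyl of compound 2, so the step most relevant is the one where furan-2-yl replaced tert-butyl, an 18-fold higher number from compound 2 to compound 3 (1.26 log units; beyond the scatter). Reversing that direction while adding a hydroxyl suggests a step down from compound 3, though less than the full return to compound 2. Compound 4 is therefore expected to give about 100 nM, within 25 nM to 400 nM, which would be an expected step of a 5.6-fold lower number from compound 3 to compound 4 (0.75 log units; beyond the scatter).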

Compound 4, inhibition constant: 240 nM
Beside the measured number, compound 4's estimate is 2.4-fold (0.38 log units) below it; low and high end bracket the measured number.
By their numbers in this assay, from the lowest: compound 1; then compound 2; then compound 4; then compound 3.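

Having no ring does not by itself bring the number back toward that of the tert-butyl group: in this assay, 1-hydroxy-1-methylpropyl still falls well short of it (a 7.7-fold higher number from compound 2 to compound 4 (0.89 log units; beyond the scatter)). Replacing furan-2-yl with this open chain, which keeps the same count of heavy atoms but adds a hydrogen-bond donor, gives only a modest gain (a 2.3-fold lower number from compound 3 to compound 4 (0.37 log units; beyond the scatter)), and the result remains far from the two-ring group of compound 1 (a 56-fold higher number from compound 1 to compound 4 (1.75 log units; beyond the scatter)). No measurement available here explains these differences.

Going by these compounds, the step from tert-butyl changes both a methyl and the chain, so the share of the hydroxyl itself stays unknown. A 1,1-dimethylpropyl group, the same chain without the hydroxyl, would separate those two changes, and a 1-amino-1-methylpropyl group would show whether an amine behaves like the hydroxyl.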